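Turning an Amino Group Back into Chlorines

The compounds below may be only part of what the source reports. "The series", "measured", "known", "first", "only" and "open" are said of these compounds alone.

compound 1 `CCCS(=O)(=O)Nc1ccc(F)c(C(=O)c2n[nH]c3ncc(-c4ccccc4Cl)cc23)c1F` — 9.3%
compound 2 `CCCS(=O)(=O)Nc1ccc(F)c(C(=O)c2n[nH]c3ncc(-c4ccccc4F)cc23)c1F` — 2%
compound 3 `CCCS(=O)(=O)Nc1ccc(F)c(C(=O)c2n[nH]c3ncc(-c4ccccc4N)cc23)c1F` — 23%

Of the compounds shown here, three sharing one core have been measured in an assay for binding affinity to dual specificity mitogen-activated protein kinase kinase 4 (Homo sapiens), read by KINOMEscan, tested at 100 nM; a lower number here means a stronger effect, a higher number a weaker effect of the compound at the concentration tested. Compound 3 stands highest of the three numbers, so it has the weakest effect at the concentration tested. The two gaps are a number 13.7 percentage points higher from compound 1 to compound 3 (beyond the scatter) and a number 21 percentage points higher from compound 2 to compound 3 (beyond the scatter); the two halogen-bearing compounds themselves differ only by a number 7.3 percentage points lower from compound 1 to compound 2 (within the scatter).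

Compound 4 `CCCS(=O)(=O)Nc1ccc(F)c(C(=O)c2n[nH]c3ncc(-c4ccc(Cl)cc4Cl)cc23)c1F` has not yet been measured. It differs from compound 3 in one place: 2,4-dichlorophenyl in place of 2-aminophenyl on an aromatic carbon. Among the compounds with values here, two measured steps bear on this change. Replacing chloro by amino on the pendant ring raised the number modestly, and replacing fluoro by amino raised it a little more. Within the data shown here, compound 4 reverses the amino-for-chloro change and adds a second chloro, for which no measured pair gives guidance. The expectation is therefore a modest step downward in this assay, of about a number 13 percentage points lower from compound 3 to compound 4 (beyond the scatter), bringing compound 4 back toward the level of compound 1. Compound 4 is estimated at 10%, with a range from 2% to 30%.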

Compound 4, a percentage reported as activity, at one concentration (the size of the read-out at that concentration, not a potency): 22%
For compound 4 the middle estimate is 12 percentage points below the measured one, and the stated range covers the measured number.
By their numbers in this assay, from the lowest: compounds 2 and 1 (each within the scatter of the next); then compounds 4 and 3 (each within the scatter of the next).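

In this assay, exchanging 2-aminophenyl for 2,4-dichlorophenyl leaves the read-out essentially unchanged (a number 1 percentage points lower from compound 3 to compound 4 (within the scatter)), so a group with no hydrogen-bond donor or acceptor cannot be told apart here from one that has one of each. The added chloro on the pendant ring of compound 1 carries a modest cost (a number 12.7 percentage points higher from compound 1 to compound 4 (beyond the scatter)), and the step from the 2-fluorophenyl group of compound 2 is of similar modest size (a number 20 percentage points higher from compound 2 to compound 4 (beyond the scatter)), so among these compounds, carrying halogen on this ring does not by itself keep the number low, as the two singly halogenated compounds had suggested. No available evidence explains why the second chloro has this effect.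

The compounds shown leave open whether the added chloro acts alone or only together with the first, which a 4-chlorophenyl group would help to separate. They also leave open how a larger or charged group at this place, such as a methoxy group or a carboxylic acid, would read in this assay.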